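Swapping the Sulfur Link: An Expectation for Compound 4

The compounds below may be only part of what the source reports. "The series", "measured", "known", "first", "only" and "open" are said of these compounds alone.

Compound 1 `O=C(/C(=C\c1ccccc1OCc1ccccc1)SCc1ccc(F)cc1)c1ccc(Cl)cc1` gives 1000 nM in a functional assay on DU-145 cells (Homo sapiens) for inhibition, read by trypan blue exclusion, with a stated time of 96 h; on this read-out higher numbers stand for weaker inhibition of growth and lower numbers for stronger inhibition of growth. Compound 2 `COc1ccccc1/C=C(/SCc1ccc(F)cc1)C(=O)c1ccc(Cl)cc1` gives 10000 nM. Compound 3 `Cc1ccc(C)c(/C=C(/SCc2ccc(F)cc2)C(=O)c2ccc(Br)cc2)c1` gives 1000 nM.

Compound 1 stands level with compound 3 at the digits printed, the two together the lowest of the three numbers; compound 2 lies furthest, a 10-fold higher number from compound 1 to compound 2 (1.00 log units; beyond the scatter). Compound 4 `Cc1ccc(CS(=O)(=O)/C(=C/c2ccccc2OCc2ccccc2)C(=O)c2ccc(Cl)cc2)cc1` differs from compound 1 in one place: (4-methylbenzyl)sulfonyl in place of (4-fluorobenzyl)sulfanyl on a double-bonded chain carbon bound to a carbonyl carbon and a double-bonded chain carbon. For the measured compounds named here, no measured step touches this group: the one step recorded, from compound 1 to compound 2, alters the oxygen-bound chain instead, and compounds 2 and 3 vary other parts, so the change stands untested. With nothing to lean on, the expected step of a 1.5-fold higher number from compound 1 to compound 4 (0.18 log units; within the scatter) is taken as none beyond the scatter, with wide uncertainty. Compound 4 is therefore estimated at 1500 nM, with a range from 300 nM to 8000 nM.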

Compound 4, concentration for 50% growth inhibition: 1000 nM
The estimate for compound 4 lay 1.5-fold (0.18 log units) above the measured number, and the stated range covers the measured number.
By their numbers in this assay, from the lowest: compounds 1, 3 and 4 (each within the scatter of the next); then compound 2.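

In this assay the only change shown at this place, (4-methylbenzyl)sulfonyl in place of (4-fluorobenzyl)sulfanyl, gives no change at the digits printed from compound 1 to compound 4 (within the scatter), so the growth-inhibition number survives a larger group on the double-bonded chain carbon. The swap alters the sulfur group and the ring substituent together, so the result cannot separate the two, and they may each do nothing or may offset each other. Nothing available explains this outcome. Still open, on these data alone, is whether a sulfinyl group, or an amine in the same place, would read the same.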